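This account rests on a few compounds, and the source may have more. Where it says the series, first, only, none or still open, it means among the compounds named here.

Working notes on the series. Compound 1 `Nc1nc(O)c2c(n1)n(C1OC(CO)[C@@H](O)[C@H]1O)c(=O)n2C/C=C/c1ccccc1` in a functional assay on the whole organism (B cells) with Mus musculus as the target (a higher number here means a larger maximal response, a lower number a smaller maximal response), gives 73%. Compound 2 `Nc1nc(O)c2c(n1)n(C1OC(CO)[C@@H](O)[C@H]1O)c(=O)n2Cc1ccc(OCc2ccccc2)cc1` in this assay gives 5%, the lowest of the two numbers at hand; its nearest neighbour is compound 1, which stands higher by an amount beyond the scatter. Compound 3 `Nc1nc(O)c2c(n1)n(C1OC(CO)[C@@H](O)[C@H]1O)c(=O)n2Cc1ccccc1` has not been measured yet. From compound 2 to compound 3 the change is hydrogen in place of benzyloxy on an aromatic carbon. Within the data shown here, no step between two measured compounds that differ in one place is available, so the size of this change has no precedent. An upward direction is expected, since compound 1 with a six-membered aromatic ring of carbon only and no benzyloxy gives 73% in this assay. The step from compound 2 to compound 3 is expected as a number 35 percentage points higher from compound 2 to compound 3 (beyond the scatter). Compound 3 is estimated at 40%, with a range from 10% to 75%.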

Compound 3, largest response reached (reported as maximal response), in percent of the reference or control that the assay uses: 110%
Estimate against measurement, compound 3: 70 percentage points below; the whole stated range lies below it.
By their numbers in this assay, from the lowest: compound 2; then compound 1; then compound 3.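

Hydrogen in place of benzyloxy on the aromatic carbon gives a number 105 percentage points higher from compound 2 to compound 3 (beyond the scatter) in this assay and so puts the first measured size on this change: the benzyloxy-bearing compound 2 sits far under the compound without that group. On the saturated chain carbon bound to an aromatic nitrogen, phenyl in place of 2-phenylethenyl gives a number 37 percentage points higher from compound 1 to compound 3 (beyond the scatter) and shows that this second position also moves the maximal response, leaving compound 3 with the largest response of the three. No measurement at hand accounts for either step.

Open, going by these compounds, is how methoxy, an amine or a carboxylic acid on that aromatic carbon would compare with hydrogen in compound 3. Also open, on these data alone, is how 2-phenylethyl, the saturated counterpart of 2-phenylethenyl, would stand on the chain carbon.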